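Cytotoxicity limits across the phthalide-type series

A few compounds are considered here, and "the series" means these few. Any claim that something is new, unique, unknown or untested is made for them only; others in the source may bear on it.

Compound 1 `Cc1noc(CC2OC(=O)c3ccccc32)n1` in an ADME assay on RAW264.7 cells (Mus musculus) for cytotoxicity, read by MTT assay, with a stated time of 24 h, in the absence of a further agent (a lower number here means a stronger inhibitor, a higher number a weaker inhibitor), gives > 40000 nM, a limit of the assay.
Compound 2 `O=C1OC(Cc2nc(Cc3ccccc3)no2)c2ccccc21` in this assay gives > 40000 nM, again a limit.
Compound 3 `CCOCCOc1ccc(C(O)C2OC(=O)c3c(OC)cc(OC)cc32)cc1` in this assay gives > 40000 nM, also a limit.

Compound 3 therefore stands where every measured value stands: at the limit of > 40000 nM in this assay, at which 3 of the 3 values shown sit. Going by the values given here, the only step between measured compounds, a step that the two limits leave unreadable from compound 1 to compound 2, is unreadable and concerns a different change. Compound 4 `COc1cc(OC)c2c(c1)C(C(O)c1ccc(OCC3CCCCC3)cc1)OC2=O` differs from compound 3 by cyclohexyl in place of ethoxymethyl on a saturated chain carbon bound to an oxygen on an aromatic ring. Among the compounds with values here, no measured step bears on this change, so no shift beyond the scatter is expected in this assay and compound 4 is expected to remain at the limit, with the step that the limit leaves unreadable from compound 3 to compound 4 estimated as flat. Compound 4 is estimated at 60000 nM, between 20000 nM and 200000 nM.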

Compound 4, half-maximal inhibitory concentration: > 40000 nM
Compound 4 gave a limit, no number (the forecaster's own chance of this, stated with the estimate: 85%); the middle value does not contradict the limit.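

Compound 4 in this assay gives > 40000 nM, a limit and not a number, so no step from compound 3 to compound 4 can be read: the limit of > 40000 nM in this assay, at which 4 of the 4 values shown sit.

The compounds shown leave open whether cyclohexyl in place of ethoxymethyl changes cytotoxicity at all.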